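A few compounds are considered here, and "the series" means these few. Any claim that something is new, unique, unknown or untested is made for them only; others in the source may bear on it.

Measured compounds in an ADME assay on Huh-5-2 cells (Homo sapiens) for cytotoxicity, read by WST assay, with a stated time of 3 days; a higher number here means that more compound is tolerated, a lower number that less compound is tolerated:
compound 1 `O=c1c(OCc2cccc(Cl)c2)c(-c2ccccc2)oc2cc(O)cc(O)c12`: 46000 nM
compound 2 `O=c1c(OCc2ccc(Cl)cc2)c(-c2ccccc2)oc2cc(O)cc(O)c12`: 36000 nM

Within the data shown here, compound 2 holds the lowest of the two numbers in this assay, but its only neighbour is compound 1, and the step of a 1.3-fold lower number from compound 1 to compound 2 (0.11 log units; within the scatter) lies within the scatter, so the two compounds cannot be ordered against each other.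

Compound 3 `O=c1c(OCc2ccc([N+](=O)[O-])cc2)c(-c2ccccc2)oc2cc(O)cc(O)c12` differs from compound 2 by nitro in place of chloro on an aromatic carbon. Among the measured compounds shown here, no measured step exchanges one group for another at that carbon; the single step in hand, a 1.3-fold lower number from compound 1 to compound 2 (0.11 log units; within the scatter), only moves chloro from one ring position to another and stays within the scatter. It bears on the present change only loosely, and the data give no reason to expect a departure from compound 2 beyond the scatter.

Compound 3 is therefore expected near compound 2 in this assay, with an estimated step of a 1.1-fold higher number from compound 2 to compound 3 (0.05 log units; within the scatter). The estimate for compound 3 is 40000 nM, with a range from 15000 nM to 100000 nM.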

Compound 3, half-maximal cytotoxic concentration: 40000 nM
Compound 3: middle estimate and measured number agree at the digits printed; measured number inside the range.
By their numbers in this assay, from the lowest: compounds 2, 3 and 1 (each within the scatter of the next).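

In this assay, among these compounds, the step of a 1.1-fold higher number from compound 2 to compound 3 (0.05 log units; within the scatter) is the first exchange of one group for another at this aromatic carbon, and with three heavy atoms entering for one, the number stays within the scatter. The step of a 1.2-fold lower number from compound 1 to compound 3 (0.06 log units; within the scatter) also lies within the scatter, so 4-nitrophenyl and 3-chlorophenyl cannot be told apart here, and none of the three compounds can be separated from the others. No measured evidence bears on this result.

From the compounds shown here alone, whether any group at this aromatic carbon can move the number beyond the scatter remains open, for instance an amine or a carboxylic acid in place of nitro. The shared core is the same in all three compounds, so the effect of a change there on tolerated concentration is also unknown.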